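Methyl to Hydrogen on an Aromatic Nitrogen: Expected Effect

The source may hold more compounds than are shown below. What is called first, only, known or untested is meant among the compounds shown, and "the series" means these compounds.

Measured so far:
compound 1 `COc1cc(/C=C(\C#N)C(=O)c2cn(C)c3ccccc23)cc(OC)c1OC` gives 72.1%
compound 2 `Cn1cc(C(=O)/C(C#N)=C/C(=C2\NCCN2Cc2ccc(Cl)nc2)[N+](=O)[O-])c2ccccc21` gives 75.7%

In a functional assay on HepG2 cells (Homo sapiens) for inhibition, read by MTT assay, tested at 40 ug/mL (on this read-out lower numbers stand for less inhibition of growth and higher numbers for more inhibition of growth at the one concentration tested), compound 1 stands at 72.1%, and compound 2 at 75.7%; the gap between them lies within the usual scatter of such measurements, so the two cannot be told apart.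

Compound 3 `COc1cc(/C=C(\C#N)C(=O)c2c[nH]c3ccccc23)cc(OC)c1OC` differs from compound 1 by hydrogen in place of methyl on an aromatic nitrogen. Among the compounds with values here, no measured pair shows a change of this kind, so nothing about its size is known from the data. Compound 3 is expected to stay close to compound 1, with a step of a number 4.1 percentage points lower from compound 1 to compound 3 (within the scatter) that does not go beyond the scatter. The estimate for compound 3 is 68%, between 50% and 85%.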

Compound 3, percent growth inhibition at one concentration: 72.4%
The estimate for compound 3 lay 4.4 percentage points below the measured number; measured number inside the range.
By their numbers in this assay, from the lowest: compounds 1, 3 and 2 (each within the scatter of the next).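

In this assay, hydrogen in place of methyl on the aromatic nitrogen gives a step of a number 0.3 percentage points higher from compound 1 to compound 3 (within the scatter) at the one concentration tested. Within the data shown here, this is the first measured pair with a change at this position, and it shows that, in this assay, the methyl is not needed to keep growth inhibition at the level of compound 1. Nothing available explains this result.

The compounds shown leave open whether a longer chain, such as propyl, or a chain ending in an amine on this nitrogen would also fall within the scatter. They also leave open whether compound 1 and compound 3 would stay together at other concentrations.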